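The compounds below may be only part of what the source reports. "The series", "measured", "known", "first", "only" and "open" are said of these compounds alone.

Compound 1 `Fc1ccc(/C=C/c2cc3ccccc3nc2Cl)cc1` and compound 2 `COc1ccc2nc(Cl)c(/C=C/c3ccc(F)cc3)cc2c1` share one core, while compound 3 `FC(F)(F)c1ccc(/C=C\c2cc3ccccc3nc2Cl)c(C(F)(F)F)c1` and compound 4 `COc1ccc2nc(Cl)c(/C=C\c3ccc(C(F)(F)F)cc3C(F)(F)F)cc2c1` share another; the difference between the two cores is not broken down here. In a functional assay on MCF7 cells (Homo sapiens) for antiproliferative activity, read by sulforhodamine B assay, with a stated time of 72 h (on this read-out higher numbers stand for weaker inhibition and lower numbers for stronger inhibition), compound 1 gives 15100 nM and compound 2 gives 14100 nM. The only difference between them is methoxy in place of hydrogen on an aromatic carbon, and this produced a 1.1-fold lower number from compound 1 to compound 2 (0.03 log units; within the scatter). In this assay, compound 3 gives 10500 nM. Compound 4 carries the same change relative to compound 3, namely (methoxy in place of hydrogen on an aromatic carbon), at a place described in the same words. Because the earlier step of a 1.1-fold lower number from compound 1 to compound 2 (0.03 log units; within the scatter) stayed within the scatter, the step to compound 4 is expected to be small as well, a 1.1-fold lower number from compound 3 to compound 4 (0.04 log units; within the scatter). In this assay, compound 4 is estimated at 9500 nM, with an expected range from 4500 nM to 20000 nM.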

Compound 4, half-maximal inhibitory concentration: > 50000 nM
Compound 4: only a limit was reported (the forecaster's own chance of this, stated with the estimate: 5%); middle value at least 5.2-fold (0.72 log units) away from the limit.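

In this assay, the same swap of hydrogen for methoxy on an aromatic carbon gave an at least 4.7-fold higher number from compound 3 to compound 4 (0.67 log units; beyond the scatter), so its effect did not carry over from one core to the other: the same change on two cores in this assay, a 1.1-fold lower number (0.03 log units; within the scatter) from compound 1 to compound 2 and an at least 4.7-fold higher number (0.67 log units; beyond the scatter) from compound 3 to compound 4, at least 5.0-fold (0.70 log units) apart, beyond the scatter of two such steps

Going by these compounds, for compound 4, > 50000 nM is a limit of the assay and not a number, so the full size of this step is unknown. These two steps show that a change with no clear effect on one core can weaken inhibition on another, but they do not show which difference between the cores matters, and they give no general rule.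

On these data alone, it remains open whether a hydroxyl or an amine at the same place would behave like methoxy on the core of compound 3. As far as these compounds go, how either group would act on the core of compound 1 is also open.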